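The compounds below may be only part of what the source reports. "The series", "measured", "known", "first", "only" and "open" are said of these compounds alone.

Measured so far in a functional assay on PANC-1 cells (Homo sapiens) for inhibition, read by MTT assay, with a stated time of 24 h; a higher number here means a weaker inhibitor, a lower number a stronger inhibitor

- compound 1 `CCOc1cc(=O)n(CCCO)c2c1CC(C/C=C(\C)CCC=C(C)C)C(C)(C)C2` gives 5800 nM
- compound 2 `CC(C)=CCC/C(C)=C/CC1Cc2c(OCCCNC(=O)c3cccs3)cc(=O)n(CCCO)c2CC1(C)C` gives 4900 nM
- compound 3 `COc1ccc(NC(=O)Oc2cc(=O)n(CCCO)c3c2CC(C/C=C(\C)CCC=C(C)C)C(C)(C)C3)cc1` gives 7100 nM

Compound 3 cannot be told apart from the other two measured compounds. The steps to it are a 1.2-fold higher number from compound 1 to compound 3 (0.09 log units; within the scatter) and a 1.4-fold higher number from compound 2 to compound 3 (0.16 log units; within the scatter) in this assay. The remaining step, a 1.2-fold lower number from compound 1 to compound 2 (0.07 log units; within the scatter), also lies within the scatter.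

The change to compound 4 `CC(C)=CCC/C(C)=C/CC1Cc2c(OC(=O)Nc3ccccc3F)cc(=O)n(CCCO)c2CC1(C)C` is 2-fluorophenyl in place of 4-methoxyphenyl on an amide-type nitrogen. The same difference, cut further out, reads (4-methoxyphenyl)carbamoyl to (2-fluorophenyl)carbamoyl. Within the data shown here, no measured step exchanges this group directly, so the evidence is indirect. Among the measured compounds shown here, two steps concern the same oxygen on the aromatic ring. Putting (4-methoxyphenyl)carbamoyl in place of ethyl gave a 1.2-fold higher number from compound 1 to compound 3 (0.09 log units; within the scatter), and putting it in place of 3-(((thiophen-2-yl)carbonyl)amino)propyl gave a 1.4-fold higher number from compound 2 to compound 3 (0.16 log units; within the scatter). Neither step leaves the scatter, so no step beyond the scatter and no direction is expected for this smaller exchange, with compound 3 at 7100 nM as the anchor.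

The expected step is a 1.2-fold lower number from compound 3 to compound 4 (0.07 log units; within the scatter) in this assay, which stays within the scatter. Compound 4 is estimated at 6000 nM with an expected range from 3000 nM to 12000 nM in this assay.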

Compound 4, half-maximal inhibitory concentration: 7400 nM
Estimate against measurement, compound 4: 1.2-fold (0.09 log units) below; low and high end bracket the measured number.
By their numbers in this assay, from the lowest: compounds 2, 1, 3 and 4 (each within the scatter of the next).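

In this assay, the direct exchange of 2-fluorophenyl for 4-methoxyphenyl on the amide-type nitrogen gives a 1.0-fold higher number from compound 3 to compound 4 (0.02 log units; within the scatter), so this position now has a measured exchange of the aryl group itself, and that exchange stays within the scatter. The ((2-fluorophenyl)carbamoyl)oxy compound also cannot be told apart from the compounds that carry other groups on the oxygen on the aromatic ring, with a 1.3-fold higher number from compound 1 to compound 4 (0.11 log units; within the scatter) for the change from ethyl and a 1.5-fold higher number from compound 2 to compound 4 (0.18 log units; within the scatter) for the change from 3-(((thiophen-2-yl)carbonyl)amino)propyl, so all four compounds remain a single flat set in this assay. Nothing available explains this flatness or connects it to any feature of the groups exchanged.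

As far as these compounds go, whether a carboxylic acid or an amine on the phenyl ring of the carbamoyl group, or a longer chain on the oxygen on the aromatic ring, would carry the number beyond the scatter remains open. The rest of the core is shared by all four compounds, so its contribution to the numbers in this assay cannot be judged from them.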